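This account rests on a few compounds, and the source may have more. Where it says the series, first, only, none or still open, it means among the compounds named here.

Measured so far in a functional assay on HCT-116 cells (Homo sapiens) for antiproliferative activity, read by MTT assay, with a stated time of 72 h; a higher number here means a weaker inhibitor, a lower number a stronger inhibitor:
- Compound 1 `Cc1noc(C)c1-c1nn(Cc2ccc(C(=O)N3CCCCC3)cc2)c(=O)c2ccccc12`: > 100000 nM
- Compound 2 `Cc1noc(C)c1-c1nn(Cc2ccc(C(=O)NC3CC(C)(C)N([O])C(C)(C)C3)cc2)c(=O)c2ccccc12`: 36800 nM

Compound 1 has a reading that is a limit of this assay and not a number: > 100000 nM. Within the data shown here, compound 2 gives 36800 nM, the only true number. Its standing can be judged only against the reading of compound 1, noted as the limit of > 100000 nM in this assay, at which 1 of the 2 values shown sits.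

Compound 3 `Cc1noc(C)c1-c1nn(Cc2ccc(C(=O)NC3CCCC3)cc2)c(=O)c2ccccc12` keeps the shared core and the amide. The change is a group of 5 heavy atoms (5 carbon; one five-membered non-aromatic ring of carbon only) in place of a group of 11 heavy atoms (9 carbon, 1 nitrogen, 1 oxygen; one six-membered non-aromatic ring with 1 hetero atom), on an amide-type nitrogen: cyclopentyl enters on an amide-type nitrogen.

Among the measured compounds shown here, one measured step bears on this. In an at least 2.7-fold lower number from compound 1 to compound 2 (0.43 log units; beyond the scatter), the larger group came with the lower number, and that step is modest and rests on a limit. As a single step, it supports only a tentative direction. Compound 3 gives up the larger group of compound 2, so part of that gain is expected to be lost, and a reading at the limit of this assay is possible.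

The expected change is a 2.2-fold higher number from compound 2 to compound 3 (0.34 log units; beyond the scatter), toward a higher number. For compound 3 the estimate is 80000 nM. The estimated range runs from 30000 nM to 100000 nM.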

Compound 3, half-maximal inhibitory concentration: > 100000 nM
Compound 3: only a limit was reported (the forecaster's own chance of this, stated with the estimate: 40%); middle value at least 1.2-fold (0.09 log units) away from the limit.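

In this assay the reading of compound 3, > 100000 nM, is a limit of the assay and not a number. With cyclopentyl on the amide-type nitrogen in place of the six-membered ring of compound 2, the series shows an at least 2.7-fold higher number from compound 2 to compound 3 (0.43 log units; beyond the scatter), so the measurable reading of compound 2 does not survive this change, and an amide hydrogen with a carbon-only five-membered ring is not enough to give a number in this assay. The step from compound 1 to compound 3 cannot be read, and the measurable range of the series still rests on compound 2 alone: the limit of > 100000 nM in this assay, at which 2 of the 3 values shown sit.

Compound 2 and compound 3 differ in ring size, in the ring hetero atom, in the oxygen and in the added carbons all at once, so the data do not tell which of these features goes with the lower number. From the compounds shown here alone, a plain cyclohexyl group on the same nitrogen, or the same six-membered ring as an amine with no oxygen on its ring nitrogen, would separate these features, and any reading for compound 3 beyond the limit stays unknown.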